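A few compounds are considered here, and "the series" means these few. Any claim that something is new, unique, unknown or untested is made for them only; others in the source may bear on it.

Measured compounds:
- Compound 1, `CCc1ccccc1OC(C)C1=NCCN1`: 282 nM
- Compound 2, `COc1ccccc1OC(C)C1=NCCN1`: 871 nM
- Compound 3, `CC(Oc1ccccc1S(C)(=O)=O)C1=NCCN1`: 51300 nM

These three compounds share one core and differ only in the group on an aromatic carbon of the six-membered carbon ring. In an assay on CHO cells for displacement of a labelled ligand from Alpha-2B adrenergic receptor (Homo sapiens) (a higher number here means a weaker inhibitor, a lower number a stronger inhibitor), compound 1 gives the lowest number of the three. The step from compound 1 to compound 2 is a 3.1-fold higher number from compound 1 to compound 2 (0.49 log units; beyond the scatter), the step from compound 1 to compound 3 is a 180-fold higher number from compound 1 to compound 3 (2.26 log units; beyond the scatter), and the step from compound 2 to compound 3 is a 59-fold higher number from compound 2 to compound 3 (1.77 log units; beyond the scatter).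

Compound 4, `CC(=O)c1ccccc1OC(C)C1=NCCN1`, has not yet been measured in this assay. It differs from compound 1 as follows: acetyl in place of ethyl on an aromatic carbon. All three measured steps bear on this change, since each replaces the group at the same aromatic carbon. Both replacements of ethyl raised the number, modestly with methoxy and strongly with methylsulfonyl. Acetyl, which brings one hydrogen-bond acceptor, is expected to land between those two outcomes, so the step from compound 1 to compound 4 is estimated at an 18-fold higher number from compound 1 to compound 4 (1.25 log units; beyond the scatter). For compound 4 the expected value is 5000 nM, within a range from 1000 nM to 25000 nM.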

Compound 4, inhibition constant: 6170 nM
Beside the measured number, compound 4's estimate is 1.2-fold (0.09 log units) below it; measured number inside the range.
By their numbers in this assay, from the lowest: compound 1; then compound 2; then compound 4; then compound 3.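

The step of a 22-fold higher number from compound 1 to compound 4 (1.34 log units; beyond the scatter) in this assay shows that a third replacement of ethyl at this aromatic carbon also raises the number, so ethyl keeps the lowest number among the four groups. Acetyl also fills the wide gap between methoxy and methylsulfonyl, with a 7.1-fold higher number from compound 2 to compound 4 (0.85 log units; beyond the scatter) on one side and an 8.3-fold lower number from compound 3 to compound 4 (0.92 log units; beyond the scatter) on the other, giving the order ethyl, methoxy, acetyl, methylsulfonyl, with each of these steps beyond the scatter. No measurement available here explains this order.

From the compounds shown here alone, it remains open whether a longer chain such as propyl, or a halogen such as chlorine, would give a lower number than ethyl. Going by these compounds, how an amine, an amide or a carboxylic acid would rank at this carbon, and whether the same order holds elsewhere on the ring, also remains unknown.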